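From furan-3-yl to ethynyl at dimethylamino

The source may report more compounds than this note shows. Statements on the series, on what has been measured and on what is new or still open speak of the compounds shown alone.

In a functional assay on K562 cells (Homo sapiens), read by MTT assay, with a stated time of 72 h (a higher number here means a weaker inhibitor, a lower number a stronger inhibitor), compound 1 `CSc1ncnc2c1c(-c1ccoc1)cn2[C@@H]1O[C@H](CO)[C@@H](O)[C@H]1O` gives 60 nM and compound 3 `CN(C)c1ncnc2c1c(-c1ccoc1)cn2[C@@H]1O[C@H](CO)[C@@H](O)[C@H]1O` gives 1540 nM, which is a 26-fold higher number from compound 1 to compound 3 (1.41 log units; beyond the scatter). Compound 2 `CNc1ncnc2c1c(-c1ccoc1)cn2[C@@H]1O[C@H](CO)[C@@H](O)[C@H]1O` reads > 20000 nM, and this is a limit. Compound 3 therefore holds the higher of the two true numbers, with an at least 12-fold lower number from compound 2 to compound 3 (1.11 log units; beyond the scatter).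

Compound 4 `C#Cc1cn([C@@H]2O[C@H](CO)[C@@H](O)[C@H]2O)c2ncnc(N(C)C)c12` differs from compound 3 as follows: ethynyl in place of furan-3-yl on an aromatic carbon. Among the measured compounds shown here, none of the measured steps touches the furan-3-yl group. Those steps, including an at least 330-fold higher number from compound 1 to compound 2 (2.52 log units; beyond the scatter), show large changes at another substituent but give no size for this exchange. No firm direction is expected, so the expected step is only a 1.3-fold higher number from compound 3 to compound 4 (0.11 log units; within the scatter). For compound 4 the estimated value is 2000 nM, with an expected range of 250 nM to 15000 nM.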

Compound 4, half-maximal inhibitory concentration: 110 nM
Beside the measured number, compound 4's estimate is 18-fold (1.26 log units) above it; measured number below the stated range.
By their numbers in this assay, from the lowest: compounds 1 and 4 (each within the scatter of the next); then compound 3. At a limit, above all of these: compound 2.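

In this assay, among the compounds shown here, ethynyl in place of furan-3-yl gives a 14-fold lower number from compound 3 to compound 4 (1.15 log units; beyond the scatter) and so shows that this position, untouched by the earlier steps, also carries a large change. With dimethylamino on the shared core, a five-membered aromatic ring is not required here, since ethynyl has no ring. Nothing shown gives a reason for this step. As far as these compounds go, whether ethynyl gives a step of similar size with methylsulfanyl or methylamino on the core stays open. Also open, from the compounds shown here alone, is how a propynyl chain or an aminomethyl group would read at this position.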